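The source may hold more compounds than are shown below. What is called first, only, known or untested is meant among the compounds shown, and "the series" means these compounds.

Values in a functional assay on A2780 cells (Homo sapiens) for inhibition; a higher number here means a weaker inhibitor, a lower number a stronger inhibitor:
- compound 1 `CCNC(=O)c1noc(-c2cc(C(C)C)c(O)cc2O)c1-c1cc(CN(C)C)no1`: 31 nM
- compound 2 `CCCn1ccc(-c2c(C(=O)NCC)noc2-c2cc(C(C)C)c(O)cc2O)n1`: 27 nM
- compound 3 `CCNC(=O)c1noc(-c2cc(C(C)C)c(O)cc2O)c1-c1ccn(C(C)C)n1`: not yet measured

Among the measured compounds shown here, the only measured step is a 1.1-fold lower number from compound 1 to compound 2 (0.06 log units; within the scatter), so compound 2 stands level with the other measured value. Compound 3 carries isopropyl in place of propyl on an aromatic nitrogen. For the measured compounds named here, no measured step changes this chain alone. Going by the values given here, the one step available exchanged a whole group and stayed within the scatter, so only weak guidance comes from it. The expected change in this assay is none beyond the scatter, an estimated 1.0-fold higher number from compound 2 to compound 3 (0.02 log units; within the scatter). Compound 3 is expected at 28 nM, within a range of 13 nM to 60 nM.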

Compound 3, half-maximal inhibitory concentration: 45 nM
The estimate for compound 3 lay 1.6-fold (0.21 log units) below the measured number, within the range that was stated.
By their numbers in this assay, from the lowest: compounds 2, 1 and 3 (each within the scatter of the next).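

In this assay, isopropyl in place of propyl on the aromatic nitrogen gives a 1.7-fold higher number from compound 2 to compound 3 (0.22 log units; within the scatter), so swapping these two chains at this position produces no step beyond the scatter. Exchanging 3-((dimethylamino)methyl)-1,2-oxazol-5-yl for 1-isopropyl-1H-pyrazol-3-yl gives a 1.5-fold higher number from compound 1 to compound 3 (0.16 log units; within the scatter), which also stays inside the scatter. No measurement at hand bears on the reason for these numbers.

Open, from the compounds shown here alone, is whether a longer chain such as butyl, or a dimethylaminoethyl chain carrying an amine, on that aromatic nitrogen would leave the number in the same range.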